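A Five-Membered Heteroaryl Returns at the Para Position

The source may hold more compounds than are shown below. What is called first, only, known or untested is meant among the compounds shown, and "the series" means these compounds.

Compound 1 `CCC(C)(C)Cc1c[nH]c(CCc2ccc(-c3csnn3)cc2)n1`: 104 nM
Compound 2 `CCC(C)(C)Cc1c[nH]c(CCc2ccc(-c3ccc(F)cn3)cc2)n1`: 97 nM

Both measured compounds share a core that ends in a benzene ring carrying a small aromatic heterocycle. In a functional assay on HEK293 cells for agonist activity at Bombesin receptor subtype-3 (Homo sapiens), read by luminescence and calcium flux, with a stated time of 10 min (a higher number here means that more compound is needed for the effect, a lower number that less compound is needed), compound 1 gives 104 nM, and compound 2 gives 97 nM. Among the compounds with values here, the only step measured, a 1.1-fold lower number from compound 1 to compound 2 (0.03 log units; within the scatter), shows that exchanging the five-membered 1,2,3-thiadiazol-4-yl for the six-membered 5-fluoropyridin-2-yl left the number where it was. On these two numbers compound 2 stands with the lower value, but the gap to compound 1 is within the scatter, so neither can be called the more potent.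

Compound 3 `CCC(C)(C)Cc1c[nH]c(CCc2ccc(-c3ccns3)cc2)n1` has not been measured. It differs from compound 2 in one place: 1,2-thiazol-5-yl in place of 5-fluoropyridin-2-yl on an aromatic carbon. The change goes back from a six-membered ring to a five-membered ring with two hetero atoms, much as compound 1 carried one, and since compound 1 and compound 2 sit so close in this assay, no step beyond the scatter is expected for compound 3, that is a 1.1-fold higher number from compound 2 to compound 3 (0.03 log units; within the scatter). Compound 3 is therefore estimated at 105 nM, with a range of 50 nM to 230 nM.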

Compound 3, half-maximal effective concentration: 102 nM
For compound 3 the middle estimate is 1.0-fold (0.01 log units) above the measured one; measured number inside the range.
By their numbers in this assay, from the lowest: compounds 2, 3 and 1 (each within the scatter of the next).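

The step of a 1.1-fold higher number from compound 2 to compound 3 (0.02 log units; within the scatter) shows, in this assay, that the place on an aromatic carbon para to a large group accepts a second exchange with no step beyond the scatter. Here a group of 7 heavy atoms with one six-membered aromatic ring gives way to a group of 5 heavy atoms with one five-membered aromatic ring, so across these compounds neither ring size nor the fluorine of 5-fluoropyridin-2-yl goes with a step that can be read. The step of a 1.0-fold lower number from compound 1 to compound 3 (0.01 log units; within the scatter) adds a comparison that the first pair could not offer, between two five-membered rings, and 1,2-thiazol-5-yl and 1,2,3-thiadiazol-4-yl cannot be told apart on these numbers. No evidence is at hand to explain why these three groups read alike.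

The compounds shown leave open whether this tolerance extends beyond small aromatic rings, for instance to a primary amine, a carboxylic acid or a plain hydrogen at the same place. They also leave open whether a larger group, such as a morpholine or a longer alkyl chain, would produce a step beyond the scatter.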